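Swapping Chlorine for Fluorine on the Dihalophenyl Ring

The compounds below may be only part of what the source reports. "The series", "measured", "known", "first", "only" and "open" are said of these compounds alone.

Going by the values given here, in a functional assay on NCI-H520 cells (Homo sapiens) (on this read-out higher numbers stand for weaker inhibition of growth and lower numbers for stronger inhibition of growth), compound 3 `O=S(=O)(/C=C/c1ccc(Cl)cc1Cl)Cc1ccc(Nc2ncnc3ccc(Br)cc23)cc1` gives 8000 nM, the lowest actual number so far. Compound 2 `O=S(=O)(/C=C/c1ccc(O)cc1)Cc1ccc(Nc2ncnc3ccc(Br)cc23)cc1` gives 27000 nM. Compound 1 `O=S(=O)(/C=C/c1ccc(Cl)c(Cl)c1)Cc1ccc(Nc2ncnc3ccc(Br)cc23)cc1` gives > 100000 nM, which is a limit of the assay and not a number.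

Compound 4 `O=S(=O)(/C=C/c1ccc(F)cc1F)Cc1ccc(Nc2ncnc3ccc(Br)cc23)cc1` has 2,4-difluorophenyl in place of 2,4-dichlorophenyl on a double-bonded chain carbon bound to a double-bonded chain carbon.

Two measured steps changed this same ring and ended at compound 3: an at least 12-fold lower number from compound 1 to compound 3 (1.09 log units; beyond the scatter), which is large, and a 3.4-fold lower number from compound 2 to compound 3 (0.53 log units; beyond the scatter), which is modest. A third, an at least 3.7-fold lower number from compound 1 to compound 2 (0.56 log units; beyond the scatter), shows that the ring also matters without the 2,4-dichlorophenyl. None of them swaps chlorine for fluorine while keeping the rest of the ring unchanged, so they show sensitivity rather than direction. With compound 3 already lowest at 8000 nM, a move upward seems likelier than a further drop.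

The expected step in this assay is small and toward a higher number, a 1.9-fold higher number from compound 3 to compound 4 (0.27 log units; within the scatter). For compound 4 the estimated value is 15000 nM, with an expected range from 5000 nM to 50000 nM.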

Compound 4, concentration for 50% growth inhibition: 100000 nM
For compound 4 the middle estimate is 6.7-fold (0.82 log units) below the measured one; the measured number lies above the stated range.
By their numbers in this assay, from the lowest: compound 3; then compound 2; then compound 4.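

With the rest of the ring kept and only the halogen changed, this position proves far from indifferent to chlorine versus fluorine: the swap gives a 13-fold higher number from compound 3 to compound 4 (1.10 log units; beyond the scatter). The 2,4-difluorophenyl group also falls behind the 4-hydroxyphenyl group, with a 3.7-fold higher number from compound 2 to compound 4 (0.57 log units; beyond the scatter), so neither two halogens on this ring nor their arrangement alone is enough to give the lowest number. Compound 1 carries a limit and not a number. That leaves a number no higher from compound 1 to compound 4 (the limit leaves the size open), which cannot be read, because the size stays open at that limit: the limit of > 100000 nM in this assay, at which 1 of the 4 values shown sits.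

From the compounds shown here alone, whether a 2,4-dibromophenyl group would go lower than the 2,4-dichlorophenyl group of compound 3, or a 2,4-dimethylphenyl group would hold that level, stays open. So does the outcome for a ring carrying one chlorine and one fluorine.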